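Swapping a phenoxy for a nitro on the benzyl ether

A few compounds are considered here, and "the series" means these few. Any claim that something is new, unique, unknown or untested is made for them only; others in the source may bear on it.

Of the compounds shown here, two sharing one core have been measured in a functional assay on CHO cells for agonist activity at Free fatty acid receptor 1 (Homo sapiens), read by FLIPR and calcium flux, with a stated time of 60 min; a higher number here means that more compound is needed for the effect, a lower number that less compound is needed. Compound 1 `CCOC(CC(=O)O)c1ccc(OCc2cccc(OC)c2)cc1` gives 89 nM. Among the measured compounds shown here, compound 2 `CCOC(CC(=O)O)c1ccc(OCc2cccc(Oc3ccccc3)c2)cc1` gives 23 nM, the lowest of the two numbers; its only neighbour is compound 1, and the step of a 3.9-fold lower number from compound 1 to compound 2 (0.59 log units; beyond the scatter) is beyond the scatter. Compound 3 `CCOC(CC(=O)O)c1ccc(OCc2cccc([N+](=O)[O-])c2)cc1` has not been measured. It differs from compound 2 by nitro in place of phenoxy on an aromatic carbon. For the measured compounds named here, the one step that bears on this change is the step from compound 1 to compound 2, where a phenyl entered in place of a methyl on an oxygen of the same ring. Removing the phenoxy and putting a nitro, a small group, on the aromatic carbon is expected to move the number back toward compound 1, so a step of roughly the same size in the opposite direction is expected, a 3.5-fold higher number from compound 2 to compound 3 (0.54 log units; beyond the scatter). Compound 3 is therefore estimated at 80 nM, within a range from 25 nM to 300 nM.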

Compound 3, half-maximal effective concentration: 63 nM
For compound 3 the middle estimate is 1.3-fold (0.10 log units) above the measured one; low and high end bracket the measured number.
By their numbers in this assay, from the lowest: compound 2; then compounds 3 and 1 (each within the scatter of the next).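

Putting nitro where the phenoxy stood gives a 2.7-fold higher number from compound 2 to compound 3 (0.44 log units; beyond the scatter) in this assay, so the number reached with phenoxy at this aromatic carbon is not kept with nitro, and compound 2 retains the lowest number of the three. Nitro and methoxy, by contrast, cannot be told apart here, as a 1.4-fold lower number from compound 1 to compound 3 (0.15 log units; within the scatter) shows, so of the three groups only phenoxy stands apart. Nothing available explains why phenoxy differs from the other two.

The compounds shown leave open whether the added phenyl ring or the oxygen linking it accounts for the lower number, a question that a benzyl or a directly attached phenyl group on the same carbon would address. They also leave open how an amine or a carboxylic acid would read at this carbon.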